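Removing the sugar from compound 2: an expected shift

The source may report more compounds than this note shows. Statements on the series, on what has been measured and on what is new or still open speak of the compounds shown alone.

The study concerns two measured glycosides and one further compound still awaiting a number. Compound 1 `COc1ccc(/C=C/C(=O)OC[C@H]2O[C@@H](O[C@H]3OC=C[C@@]4(O)[C@@H]3[C@](C)(O)C[C@@H]4O)[C@H](O)[C@@H](O)[C@@H]2O)cc1OC` and compound 2 `COc1ccc(/C=C/C(=O)OC[C@H]2O[C@@H](O[C@H]3OC=C[C@@]4(O)[C@@H]3[C@](C)(O)C[C@@H]4O)[C@H](O[C@@H]3O[C@H](CO)[C@@H](O)[C@H](O)[C@H]3O)[C@@H](O)[C@@H]2O)cc1` were both tested in a functional assay for inhibition, with a stated time of 24 h; on this read-out lower numbers stand for stronger inhibition and higher numbers for weaker inhibition. In this assay compound 1 gives 26500 nM, while compound 2 gives 12900 nM. Compound 2 therefore stands at the lowest of the two numbers, and its distance from compound 1 lies beyond the usual scatter. The two measured compounds differ in more than one place, so only their two values can be compared here.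

Compound 3 `COc1ccc(/C=C/C(=O)OC[C@H]2O[C@@H](O[C@H]3OC=C[C@@]4(O)[C@@H]3[C@](C)(O)C[C@@H]4O)[C@H](O)[C@@H](O)[C@@H]2O)cc1` is derived from compound 2 by a single change: hydrogen in place of 3,4,5-trihydroxy-6-(hydroxymethyl)oxan-2-yl on an oxygen on a saturated carbon. For the measured compounds named here, compound 3 has no measurement yet. Going by the values given here, since no single-change step between measured compounds is available, the expectation for compound 3 can rest only on the two values shown. A modest upward step, near the edge of the scatter, is expected, namely a 1.6-fold higher number from compound 2 to compound 3 (0.19 log units; within the scatter). For compound 3 the estimated value in this assay is 20000 nM, with a range from 8000 nM to 50000 nM.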

Compound 3, half-maximal inhibitory concentration: 13200 nM
Estimate against measurement, compound 3: 1.5-fold (0.18 log units) above, and the stated range covers the measured number.
By their numbers in this assay, from the lowest: compounds 2, 3 and 1 (each within the scatter of the next, the first and the last beyond it).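

In this assay, the loss of 3,4,5-trihydroxy-6-(hydroxymethyl)oxan-2-yl from an oxygen on a saturated carbon comes to a step within the scatter (a 1.0-fold higher number from compound 2 to compound 3 (0.01 log units; within the scatter)), so this assay cannot tell the compound with the whole sugar unit from the one with a plain hydroxy group at that place. Compound 3 also links compound 1 to the series through a single change, hydrogen in place of methoxy on an aromatic carbon, and this step too is printed as within the scatter, though at its edge (a 2.0-fold lower number from compound 1 to compound 3 (0.30 log units; within the scatter)). The data offer no measured explanation for either step.

The compounds shown leave open whether an amine or a carboxylic acid on that saturated carbon, or a longer chain in place of the methoxy on the aromatic carbon, would move the number beyond the scatter. Also open, on these data alone, is whether the 3,4,5-trihydroxy-6-(hydroxymethyl)oxan-2-yl group would count for as little on a compound that also carries the methoxy group.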